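Chain Homologation in a Series of Cholesterol Acyltransferase Inhibitors

A few compounds are considered here, and "the series" means these few. Any claim that something is new, unique, unknown or untested is made for them only; others in the source may bear on it.

Measured compounds:
Compound 1, `CCCCCCCCCCCCC(C)OC(=O)NC(=O)Nc1c(C(C)C)cccc1C(C)C`: 46 nM
Compound 2, `CCCCCCCCCCCCC(C)(C)OC(=O)NC(=O)Nc1c(C(C)C)cccc1C(C)C`: 65 nM
Compound 3, `CCCCCCCCCCOC(=O)NC(=O)Oc1c(C(C)C)cccc1C(C)C`: 74 nM

In an assay on microsomes from intestine for inhibition of acyl-CoA:cholesterol acyltransferase (Oryctolagus cuniculus) (a lower number here means a stronger inhibitor, a higher number a weaker inhibitor), compound 1 gives 46 nM and compound 2 gives 65 nM. The change between them, (methyl in place of hydrogen on a saturated chain carbon bound to an oxygen next to a carbonyl group and two saturated chain carbons), made a step of a 1.4-fold higher number from compound 1 to compound 2 (0.15 log units; within the scatter). Compound 3 gives 74 nM in this assay; its value sits close to those of compound 1 and compound 2. The difference between the core of compound 1 and the core of compound 3 is not broken down here.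

Compound 4, `CCCCCCCCCCCOC(=O)NC(=O)Oc1c(C(C)C)cccc1C(C)C`, is not yet measured. It carries the change (methyl in place of hydrogen on a saturated chain carbon, ten or more bonds along the chain from an oxygen next to a carbonyl group), the same kind of change as from compound 1 to compound 2, but at a different place: there the carbon was bound to an oxygen next to a carbonyl group and two saturated chain carbons, here it lies further out along the chain from that oxygen. Since compound 1 to compound 2 gave a 1.4-fold higher number from compound 1 to compound 2 (0.15 log units; within the scatter), an equally small step is expected, estimated as a 1.1-fold lower number from compound 3 to compound 4 (0.02 log units; within the scatter). Compound 4 is therefore expected to give about 70 nM in this assay, estimated between 35 nM and 150 nM.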

Compound 4, half-maximal inhibitory concentration: 140 nM
Compound 4: middle estimate off by 2.0-fold (0.30 log units), on the low side; the measured number falls inside the stated range.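

In this assay, methyl in place of hydrogen on a saturated chain carbon, ten or more bonds along the chain from an oxygen next to a carbonyl group, gave a 1.9-fold higher number from compound 3 to compound 4 (0.28 log units; within the scatter). Set beside the earlier step, the change carries from one core to the other without a discernible difference: the same change on two cores in this assay, a 1.4-fold higher number (0.15 log units; within the scatter) from compound 1 to compound 2 and a 1.9-fold higher number (0.28 log units; within the scatter) from compound 3 to compound 4, 1.3-fold (0.13 log units) apart, within the scatter of two such steps

This holds for these two pairs only, and the two steps differ in their place on the chain as well as in their core, so it does not show that the change would read alike on other cores or at other places.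

The compounds shown leave open how a longer chain would read on either core in this assay. They also leave open what an amine or a carboxylic acid at the end of the chain would do there.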